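This account rests on a few compounds, and the source may have more. Where it says the series, first, only, none or still open, it means among the compounds named here.

Measured compounds, with maximal response in an assay on NIH3T3 cells with Urotensin-2 receptor (Homo sapiens) as the target; on this read-out lower numbers stand for smaller maximal responses and higher numbers for larger maximal responses:
compound 1 `Cc1ccsc1C(=O)OC(CCN(C)C)c1ccc(Cl)cc1`: 119%
compound 2 `Cc1cccc(C(=O)OC(CCN(C)C)c2ccc(Cl)cc2)c1C`: 91%
compound 3 `Cc1ccccc1NC(=O)OC(CCN(C)C)c1ccc(Cl)cc1`: 176%

Compound 3 stands highest of the three in this assay. Its nearest neighbour on the numbers is compound 1, and the gap is beyond the scatter: a number 57 percentage points higher from compound 1 to compound 3 (beyond the scatter). Compound 2 lies furthest away, again beyond the scatter: a number 85 percentage points higher from compound 2 to compound 3 (beyond the scatter). Both large rises share the same change at the carbonyl carbon, an ester group giving way to a carbamate bearing (2-methylphenyl)amino. The smaller shift among the two esters, a number 28 percentage points lower from compound 1 to compound 2 (beyond the scatter), is modest.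

Compound 4 `CN(C)CCC(OC(=O)NCc1ccccc1)c1ccc(Cl)cc1` keeps the carbamate of compound 3 and alters only what hangs on its nitrogen: benzyl in place of 2-methylphenyl on an amide-type nitrogen. Among the compounds with values here, no measured step touches this position; all three recorded steps vary the group on the carbonyl carbon, so the benzyl case has no direct precedent. The carbamate itself, common to compound 3 and compound 4, is what the large steps point to, so the value of compound 4 is expected to stay above the two esters, while the swap of 2-methylphenyl for benzyl is expected to cost some response rather than add to it. The step from compound 3 to compound 4 is therefore estimated as a number 36 percentage points lower from compound 3 to compound 4 (beyond the scatter), beyond the scatter but leaving compound 4 clearly above compound 1. For compound 4 the expected maximal response is 140%, with a range from 100% to 180%.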

Compound 4, largest response reached (reported as efficacy), in percent of the reference or control that the assay uses: 180%
For compound 4 the middle estimate is 40 percentage points below the measured one; the range from low to high includes it.
By their numbers in this assay, from the lowest: compound 2; then compound 1; then compounds 3 and 4 (each within the scatter of the next).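

In this assay, within the data shown here, the change on the amide-type nitrogen from 2-methylphenyl to benzyl gives a number 4 percentage points higher from compound 3 to compound 4 (within the scatter), the first reading at this position, and the two groups are not told apart there. The high response of the carbamates is therefore not tied to 2-methylphenyl: with benzylamino on the carbonyl carbon the rises over the esters remain, at a number 89 percentage points higher from compound 2 to compound 4 (beyond the scatter) and a number 61 percentage points higher from compound 1 to compound 4 (beyond the scatter), and among these four compounds neither ester goes against this split. Nothing at hand explains why these two groups on the nitrogen read alike.

From the compounds shown here alone, both groups compared on this nitrogen carry a six-membered aromatic ring of carbon only, so it stays open whether the high response survives with a plain methyl, a cyclohexyl or a longer 2-phenylethyl chain in their place. Going by these compounds, it also stays open whether the carbamate oxygen is needed, which a urea or an amide in its place would test against compound 3 and compound 4.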